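Pyrazole to imidazole on the aryl ring of a urea

This account rests on a few compounds, and the source may have more. Where it says the series, first, only, none or still open, it means among the compounds named here.

Of the compounds shown here, two sharing one core have been measured in a functional assay on a cell-free system (plasma) with sterol O-acyltransferase, Soat (Rattus norvegicus) as the target; on this read-out higher numbers stand for an effect only at larger amounts of compound and lower numbers for an effect already at smaller amounts. Compound 1 `Cc1cc(C)c(NC(=O)N(Cc2ccc(-c3cccs3)cc2)C2CCCCCC2)c(C)c1` gives 0.28 mg/kg. Compound 2 `Cc1cc(C)c(NC(=O)N(Cc2ccc(-c3cn[nH]c3)cc2)C2CCCCCC2)c(C)c1` gives only a limit in this assay, > 1 mg/kg. From the compounds shown here alone, the exchange of 1H-pyrazol-4-yl for thiophen-2-yl on an aromatic carbon brought an at least 3.5-fold higher number from compound 1 to compound 2 (0.55 log units; beyond the scatter); the true size of that step stays open because compound 2 sits at the limit of > 1 mg/kg in this assay, at which 1 of the 2 values shown sits.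

Compound 3 `Cc1cc(C)c(NC(=O)N(Cc2ccc(-n3ccnc3)cc2)C2CCCCCC2)c(C)c1` has not been measured. It differs from compound 2 in one place: 1H-imidazol-1-yl in place of 1H-pyrazol-4-yl on an aromatic carbon. Within the data shown here, no measured step covers this exchange, and the single step that is known touches a different group, so it offers no direct guide. Compound 3 is expected to show a step that the limit leaves unreadable from compound 2 to compound 3. The estimate for compound 3 in this assay is 2 mg/kg, likely between 0.7 mg/kg and 6 mg/kg, with a fair chance that only a limit is reported again.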

Compound 3, dose for half-maximal effect: > 1 mg/kg
Compound 3: no number, only a limit (the forecaster's own chance of this, stated with the estimate: 65%); the middle value does not contradict the limit.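

The exchange of thiophen-2-yl for 1H-imidazol-1-yl at this place, para to a large group, brought an at least 3.5-fold higher number from compound 1 to compound 3 (0.55 log units; beyond the scatter), so the rise seen with 1H-pyrazol-4-yl also appears with a second ring. The two rings differ in what they carry: 1H-pyrazol-4-yl has 1 hydrogen-bond donor and 1H-imidazol-1-yl has 0 hydrogen-bond donors, so a donor on the ring is not needed for the rise over compound 1. The two ring isomers cannot be ranked, and the step between them cannot be read because both results are limits: the limit of > 1 mg/kg in this assay, at which 2 of the 3 values shown sit.

From the compounds shown here alone, how far either compound lies beyond that limit in this assay stays open. Also open, going by these compounds, is whether a ring with nitrogen is what matters, which a furan-2-yl or a plain phenyl group at this place would help to show.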